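This account rests on a few compounds, and the source may have more. Where it says the series, first, only, none or still open, it means among the compounds named here.

Three compounds share one core and were tested in a functional assay on the whole organism (artery, strain albino) with Rattus norvegicus as the target, with a stated time of 180 min, at a dose of 10 mg/kg by the oral route; on this read-out higher numbers stand for more inhibition at the one dose given (going by the name of the read-out) and lower numbers for less inhibition. Compound 1, `COc1ccc(C2N=C(SCc3ccccc3Cl)NC(C)=C2C(=O)Nc2ccc(F)cc2)cc1OC`, gives 25.3% in this assay. Compound 2, `CC1=C(C(=O)Nc2ccc(F)cc2)C(c2ccc([N+](=O)[O-])cc2)N=C(SCc2ccccc2)N1`, gives 23.7% in this assay. Compound 3, `CC1=C(C(=O)Nc2ccc(Br)cc2)C(c2ccc(Cl)cc2Cl)N=C(SCc2ccccc2)N1`, gives 13.4% in this assay, which is the lowest of the three numbers; its gap to compound 2 and its larger gap to compound 1 both lie beyond the scatter of repeated measurements, so the inhibition of compound 3 in this assay is lower than that of the other two.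

Compound 4, `CC1=C(C(=O)Nc2ccc(Br)cc2)C(c2ccc(Cl)cc2Cl)N=C(SCc2ccc(F)cc2)N1`, has not yet been measured. It differs from compound 3 in one place only: fluoro in place of hydrogen on an aromatic carbon. Within the data shown here, no pair of measured compounds shows this particular change, so there is no measured step to lean on.

With so small a change at that place, no step beyond the scatter is expected in this assay; the expected step is a number 1.6 percentage points higher from compound 3 to compound 4 (within the scatter). Compound 4 is therefore estimated to give about 15% in this assay, within a range from 5% to 27%.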

Compound 4, a percentage reported as inhibition, in the whole organism at one dose (the size of the read-out at that dose, not a potency): 28.4%
Estimate against measurement, compound 4: 13.4 percentage points below, and the stated range ends below it.
By their numbers in this assay, from the lowest: compound 3; then compounds 2, 1 and 4 (each within the scatter of the next).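

In this assay, replacing one hydrogen with fluoro on the benzyl ring of compound 3 gives a number 15 percentage points higher from compound 3 to compound 4 (beyond the scatter). This step shows that the aromatic carbon para to a large group is not a silent position: in this pair, the change from benzyl to 4-fluorobenzyl, which adds just one heavy atom, is enough to move the read-out beyond the usual scatter. Nothing measured here explains the rise.

On these data alone, it remains open whether the rise is specific to fluoro or whether an amine or a carboxylic acid at this same carbon would change the number as well. As far as these compounds go, it also remains open whether the step would carry over to compounds with different groups elsewhere on the shared core, or hold at other doses, since each number comes from a single dose.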